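Amide Nitrogen Methylation Across Two Aryl Variants

The source may hold more compounds than are shown below. What is called first, only, known or untested is meant among the compounds shown, and "the series" means these compounds.

Compound 1 `O=C(Nc1nc(-c2cccc(Br)c2)cs1)c1ccccc1` gives 10000 nM in a functional assay on MDA-MB-231 cells (Homo sapiens), read by microscopy and transwell migration, with a stated time of 24 h; a higher number here means a weaker inhibitor, a lower number a stronger inhibitor. Compound 3 `CN(C(=O)c1ccccc1)c1nc(-c2cccc(Br)c2)cs1` differs from it only by methyl in place of hydrogen on an amide-type nitrogen, and in this assay compound 3 gives 437 nM. That single change produced a 23-fold lower number from compound 1 to compound 3 (1.36 log units; beyond the scatter).

Compound 2 `Cc1ccc(-c2cnc(NC(=O)c3ccccc3)s2)cc1` carries a different aryl group on the shared core; the difference between the two cores is not broken down here. In this assay compound 2 gives 308 nM, the lowest of the three numbers, although its gap to compound 3 lies within the scatter, so the two cannot be ordered.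

Compound 4 `Cc1ccc(-c2cnc(N(C)C(=O)c3ccccc3)s2)cc1` is the counterpart of compound 2 made by methyl in place of hydrogen on an amide-type nitrogen. Going by the values given here, this is the same change as the one from compound 1 to compound 3, at the same place on the amide-type nitrogen, and it occurs twice in the set.

The expectation for compound 4 rests on a single precedent. The change is estimated to lower the number again, but by a smaller amount than the earlier step, because compound 2 already starts at 308 nM, close to where compound 3 finished at 437 nM. The expected step is a 2.6-fold lower number from compound 2 to compound 4 (0.41 log units; beyond the scatter). Compound 4 is therefore estimated at 120 nM in this assay, with a likely range from 25 nM to 600 nM.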

Compound 4, half-maximal inhibitory concentration: 1090 nM
For compound 4 the middle estimate is 9.1-fold (0.96 log units) below the measured one; measured number outside the range, above it.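

In this assay, methyl in place of hydrogen on the amide-type nitrogen does not carry over from one core to the other with a fixed size or even a fixed direction; on the second core the change gives a 3.5-fold higher number from compound 2 to compound 4 (0.55 log units; beyond the scatter), and the two steps differ by more than scatter can account for: the same change on two cores in this assay, a 23-fold lower number (1.36 log units; beyond the scatter) from compound 1 to compound 3 and a 3.5-fold higher number (0.55 log units; beyond the scatter) from compound 2 to compound 4, 81-fold (1.91 log units) apart, beyond the scatter of two such steps

For this series, then, a gain from this change on one core is no guide to its outcome on another, and the result for the core of compound 1 cannot be treated as a rule. Going by these compounds alone, with only one matched pair per core, this shows a dependence on the core but not which feature of the cores is responsible, and it says nothing about why the direction reverses.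

Going by these compounds, it remains open whether a third aryl group on the shared core would follow the pattern of compound 1 or that of compound 2, which would show whether either step is typical. Also open, on these data alone, is how ethyl, a longer chain or a chain ending in an amine on the same nitrogen would behave on each of the two cores.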